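Swapping Nitro for Chloro on a Weakly Active Core

This account rests on a few compounds, and the source may have more. Where it says the series, first, only, none or still open, it means among the compounds named here.

Compound 1 `O=[N+]([O-])c1ccc(-c2csc(N3N=C(c4ccc(N5CCCCC5)cc4)CC3c3ccc(Cl)cc3)n2)cc1` was tested in a functional assay on A549 cells (Homo sapiens) for antiproliferative activity, read by MTT assay, with a stated time of 72 h; on this read-out lower numbers stand for stronger inhibition and higher numbers for weaker inhibition. There compound 1 gives > 100000 nM, which is a limit of the assay rather than a number (the limit of > 100000 nM in this assay, at which 1 of the 2 values shown sits). Compound 2 `Fc1ccc(-c2csc(N3N=C(c4ccc(N5CCCCC5)cc4)CC3c3ccc(Cl)cc3)n2)cc1` carries fluoro in place of nitro; in this assay compound 2 gives 70200 nM, a step of an at least 1.4-fold lower number from compound 1 to compound 2 (0.15 log units; that floor lies within the scatter). Compound 3 `Clc1ccc(-c2csc(N3N=C(c4ccc(N5CCCCC5)cc4)CC3c3ccc(Cl)cc3)n2)cc1` differs from compound 1 by chloro in place of nitro on an aromatic carbon. Among the compounds with values here, the only comparable step is the small one to compound 2, so for compound 3 a step of about an at least 1.5-fold lower number from compound 1 to compound 3 (0.18 log units; that floor lies within the scatter) toward a lower number is expected. Compound 3 is estimated at 65000 nM, within 25000 nM to 150000 nM.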

Compound 3, half-maximal inhibitory concentration: 46400 nM
Estimate against measurement, compound 3: 1.4-fold (0.15 log units) above; the range from low to high includes it.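

In this assay, within the data shown here, an at least 2.1-fold lower number from compound 1 to compound 3 (0.33 log units; beyond the scatter) is the first step at this position that clearly exceeds the scatter, since the floor of the step to the fluoro compound did not. From the compounds shown here alone, its true size remains unknown, as compound 1 gives only a limit and not a number: the limit of > 100000 nM in this assay, at which 1 of the 3 values shown sits. The two halogens cannot be told apart here, given a 1.5-fold lower number from compound 2 to compound 3 (0.18 log units; within the scatter).

Still open, going by these compounds, is how an amine, a methoxy group or a carboxylic acid would read on this aromatic carbon. Whether any group there would bring a much lower number also remains unanswered.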